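The source may hold more compounds than are shown below. What is called first, only, known or untested is meant among the compounds shown, and "the series" means these compounds.

In a functional assay on U-937 cells (Homo sapiens) for cytotoxicity, read by MTT assay, with a stated time of 24 h (a lower number here means a stronger inhibitor, a higher number a weaker inhibitor), compound 1 (`O=c1c2c(C(F)(F)F)cc(-c3ccccc3)nc2ncn1Cc1cn(CCC(F)(F)C(F)(F)C(F)(F)C(F)(F)C(F)(F)C(F)(F)C(F)(F)C(F)(F)F)nn1`) stands at > 200 ug/mL as a limit of the assay, not a number. On the same shared core with a different chain, compound 2 (`CCCCCCCCCCn1cc(Cn2cnc3nc(-c4ccccc4)cc(C(F)(F)F)c3c2=O)nn1`) gives 8.16 ug/mL in this assay. Compound 3 (`CCCCCCCCCCn1cc(Cn2c(C)nc3nc(-c4ccccc4)cc(C(F)(F)F)c3c2=O)nn1`) gives 6.2 ug/mL there.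

Compound 4 (`CCCCCCc1nc2nc(-c3ccccc3)cc(C(F)(F)F)c2c(=O)n1Cc1cn(CCC(F)(F)C(F)(F)C(F)(F)C(F)(F)C(F)(F)C(F)(F)C(F)(F)C(F)(F)F)nn1`) departs from compound 1 in one place (hexyl in place of hydrogen on an aromatic carbon), between two ring nitrogen atoms. Among the measured compounds shown here, the only measured step at an aromatic carbon is a 1.3-fold lower number from compound 2 to compound 3 (0.12 log units; within the scatter) with methyl in place of hydrogen. That step involves methyl rather than hexyl and was measured with the other chain, so it is only a weak guide here. No step beyond the scatter is therefore expected in this assay, and the estimated change (an at least 1.1-fold lower number from compound 1 to compound 4 (0.04 log units; that floor lies within the scatter)) is small. Compound 4 is expected at about 180 ug/mL in an estimated range from 60 ug/mL to 300 ug/mL, and it may well be reported only as a limit.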

Compound 4, half-maximal inhibitory concentration: > 200 ug/mL
Compound 4 ended at the assay's limit; the forecaster's own chance of this, stated with the estimate: 55%; middle value at least 1.1-fold (0.04 log units) from the limit.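

Compound 1 and compound 4 both stand at a limit of the assay rather than at a number, so no step can be read between them in this assay: the limit of > 200 ug/mL in this assay, at which 2 of the 4 values shown sit. The compounds shown leave open whether hexyl in place of hydrogen changes the cytotoxicity read-out at all, and in which direction.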